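Removing the Protecting Group on a Second Core

The source may hold more compounds than are shown below. What is called first, only, known or untested is meant among the compounds shown, and "the series" means these compounds.

Compound 1, `CC(C)(C)OC(=O)N(Cc1ccco1)C(=O)c1ccc(CN2Cc3ccccc3S2(=O)=O)cc1`, gives 10600 nM in a functional assay on RAW264.7 cells (Mus musculus) for inhibition; a higher number here means a weaker inhibitor, a lower number a stronger inhibitor.
Compound 2, `O=C(NCc1ccco1)c1ccc(CN2Cc3ccccc3S2(=O)=O)cc1`, gives 68400 nM in this assay.
Compound 3, `CC(C)(C)OC(=O)N(Cc1ccco1)C(=O)c1ccc(Cn2sc3ccccc3c2=O)cc1`, gives 68000 nM in this assay.

Two changes have been measured on the core of compound 1. The first is hydrogen in place of tert-butoxycarbonyl on an amide-type nitrogen, which gave a 6.5-fold higher number from compound 1 to compound 2 (0.81 log units; beyond the scatter). The second swaps one ring system for another, (a group of 10 heavy atoms (7 carbon, 1 nitrogen, 1 oxygen, 1 sulfur; one five-membered aromatic ring with 2 hetero atoms, one six-membered aromatic ring of carbon only) in place of a group of 11 heavy atoms (7 carbon, 1 nitrogen, 2 oxygen, 1 sulfur; one five-membered non-aromatic ring with 2 hetero atoms, one six-membered aromatic ring of carbon only), on a saturated chain carbon bound to an aromatic carbon), and gave a 6.4-fold higher number from compound 1 to compound 3 (0.81 log units; beyond the scatter). The values of compound 2 and compound 3 lie within the usual scatter of each other, so no order between them can be read.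

Compound 4, `O=C(NCc1ccco1)c1ccc(Cn2sc3ccccc3c2=O)cc1`, has not been measured. It carries the core of compound 3 with the same change already seen once: hydrogen in place of tert-butoxycarbonyl on an amide-type nitrogen. The place of the change is described in the same words in both pairs, so this is the same change, here on the other core. Its step is expected to be a 5.1-fold higher number from compound 3 to compound 4 (0.71 log units; beyond the scatter), close to the earlier one, because that change gave a 6.5-fold higher number from compound 1 to compound 2 (0.81 log units; beyond the scatter). For compound 4 the value in this assay is estimated at 350000 nM, expected between 120000 nM and 1000000 nM.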

Compound 4, half-maximal inhibitory concentration: 19800 nM
Beside the measured number, compound 4's estimate is 18-fold (1.25 log units) above it; the whole stated range lies above it.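

On the second core, hydrogen in place of tert-butoxycarbonyl on the amide-type nitrogen gave a 3.4-fold lower number from compound 3 to compound 4 (0.54 log units; beyond the scatter) in this assay, so here the loss of the group goes with a stronger inhibitor. On these two cores, the same change does not carry over, even in direction: the same change on two cores in this assay, a 6.5-fold higher number (0.81 log units; beyond the scatter) from compound 1 to compound 2 and a 3.4-fold lower number (0.54 log units; beyond the scatter) from compound 3 to compound 4, 22-fold (1.35 log units) apart, beyond the scatter of two such steps This shows that the result of this change depends on the core that carries it, so a step measured on one core was a poor guide to the other; it does not show what in the two cores causes the difference, and two pairs give no rule for any further core.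

The compounds shown leave open how a small group such as methyl or acetyl on that amide-type nitrogen would act on each core, and whether it would follow the pattern of the hydrogen or of the tert-butoxycarbonyl. A third core carrying the same change could show which of the two opposite steps is the more usual one.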